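The source may hold more compounds than are shown below. What is called first, only, known or untested is meant among the compounds shown, and "the series" means these compounds.

In a functional assay on CCRF-CEM cells (Homo sapiens) for inhibition (a lower number here means a stronger inhibitor, a higher number a weaker inhibitor), the series stands as follows:
- compound 1 `O=C1/C(=C/c2ccccc2Cl)Cc2ccccc21` gives 57000 nM
- compound 2 `O=C1/C(=C/c2ccccc2[N+](=O)[O-])Cc2ccccc21` gives 3530 nM
- compound 3 `O=C1/C(=C/c2ccccc2Br)Cc2ccccc21` is not yet measured

Compound 2 holds the lower of the two numbers. The change to compound 3 is bromo in place of nitro on an aromatic carbon. Within the data shown here, the only measured step bearing on this is a 16-fold lower number from compound 1 to compound 2 (1.21 log units; beyond the scatter), a large one beyond the scatter, for nitro in place of chloro. Going by that step and by compound 1 at 57000 nM, a large rise in the number in this assay is expected, with no certainty that bromo tracks chloro. The expected change is an 11-fold higher number from compound 2 to compound 3 (1.05 log units; beyond the scatter) as an estimate. Compound 3 is estimated at 40000 nM, with an expected range of 12000 nM to 110000 nM here.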

Compound 3, half-maximal inhibitory concentration: 46800 nM
Compound 3: middle estimate off by 1.2-fold (0.07 log units), on the low side, within the range that was stated.
By their numbers in this assay, from the lowest: compound 2; then compounds 3 and 1 (each within the scatter of the next).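

In this assay bromo in place of nitro on the aromatic carbon gives a 13-fold higher number from compound 2 to compound 3 (1.12 log units; beyond the scatter) and so sets the number of compound 2 against two halogens rather than one. Bromo and chloro do not separate at this position, the step being a 1.2-fold lower number from compound 1 to compound 3 (0.09 log units; within the scatter) and within the scatter, so among the groups shown only nitro stands apart. No measurement here accounts for the difference between nitro and the halogens.

The compounds shown leave open whether an amine, a methoxy group or a nitrile on the same carbon would fall with nitro or with the halogens. From the compounds shown here alone, whether fluoro would stay with chloro and bromo also remains open.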